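Aryl variation on the fluoropiperidine side chain

The compounds below may be only part of what the source reports. "The series", "measured", "known", "first", "only" and "open" are said of these compounds alone.

Among the compounds with values here, compound 2 `Fc1ccccc1CCC1(F)CCN(CCCc2c[nH]c3ccc(-n4cnnc4)cc23)CC1` gives 16 nM in an assay on CHO cells for displacement of a labelled ligand from 5-hydroxytryptamine receptor 1B (Homo sapiens) (a higher number here means a weaker inhibitor, a lower number a stronger inhibitor), the larger of the two numbers measured so far, though its nearest neighbour compound 1 `FC1(Cc2ccccc2)CCN(CCCc2c[nH]c3ccc(-n4cnnc4)cc23)CC1` gives 15 nM and the step of a 1.1-fold higher number from compound 1 to compound 2 (0.03 log units; within the scatter) lies within the scatter. Compound 3 `CC(CC1(F)CCN(CCCc2c[nH]c3ccc(-n4cnnc4)cc23)CC1)c1ccccc1` carries 1-phenylethyl in place of 2-fluorobenzyl on a saturated chain carbon bound to a saturated ring carbon. Within the data shown here, the one measured step bearing on this, a 1.1-fold higher number from compound 1 to compound 2 (0.03 log units; within the scatter), exchanged the substituent at the same place without moving beyond the scatter, so no step beyond the scatter is expected here either. Compound 3 is therefore estimated at 18 nM, within 8 nM to 40 nM. The expected step is a 1.1-fold higher number from compound 2 to compound 3 (0.05 log units; within the scatter), within the scatter.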

Compound 3, half-maximal inhibitory concentration: 28 nM
Estimate against measurement, compound 3: 1.6-fold (0.19 log units) below; the range from low to high includes it.
By their numbers in this assay, from the lowest: compounds 1, 2 and 3 (each within the scatter of the next).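

In this assay, 1-phenylethyl at this place, on a saturated chain carbon bound to a saturated ring carbon, gives two steps (a 1.8-fold higher number from compound 2 to compound 3 (0.24 log units; within the scatter); a 1.9-fold higher number from compound 1 to compound 3 (0.27 log units; within the scatter)), both within the scatter. The place thus holds a branched aryl side chain as well as the unbranched ones, with no step beyond the scatter so far. No available evidence bears on these numbers. Still open, going by these compounds, is whether an amine, a carboxylic acid or a longer chain here would move beyond the scatter. The loss of the ring fluorine and the branching also remain unseparated.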